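The compounds below may be only part of what the source reports. "The series", "measured", "known", "first", "only" and "open" are said of these compounds alone.

Measured so far:
compound 1 `CS(=O)(=O)c1ccc(C(=O)N2CCC(C(=O)N3CCc4ccccc43)CC2)cc1[N+](=O)[O-]` — > 60000 nM
compound 2 `CN(Cc1cccc(F)c1)C(=O)CCCNC(=O)c1ccc(S(C)(=O)=O)c([N+](=O)[O-])c1` — > 60000 nM
compound 3 `CN(CC(=O)N1CCN(c2ccc(F)cc2)CC1)C(=O)c1ccc(S(C)(=O)=O)c([N+](=O)[O-])c1` — > 60000 nM

In an assay on isolated protein for inhibition of vitamin D3 receptor (Homo sapiens), read by fluorescence polarization (on this read-out lower numbers stand for stronger inhibition and higher numbers for weaker inhibition), compound 1 gives only a limit, not a number. Compound 2 likewise gives only a limit in this assay. Compound 3 too sits at a limit. Across the three, the common feature is the limit of > 60000 nM in this assay, at which 3 of the 3 values shown sit, so no step between measured compounds can be sized here.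

Compound 4 `CN1CCN(C(=O)C2CCN(C(=O)c3ccc(S(C)(=O)=O)c([N+](=O)[O-])c3)CC2)CC1` differs from compound 1 in one place: 4-methylpiperazin-1-yl in place of 2,3-dihydro-1H-indol-1-yl on a carbonyl carbon. With every measured value at the limit, no direction for this change can be read from the shared core. The expectation for the step from compound 1 to compound 4 is a step that the limit leaves unreadable from compound 1 to compound 4, meaning no gain beyond the scatter. Compound 4 is therefore estimated at 80000 nM, with a range from 30000 nM to 300000 nM.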

Compound 4, half-maximal inhibitory concentration: > 60000 nM
Compound 4: a limit, no number; the forecaster's own chance of this, stated with the estimate: 85%; the middle value is on the limit's open side.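

In this assay compound 1 and compound 4 both give only a limit, so no step can be read between them. The compounds shown leave open which change to the shared core, if any, would give a measurable value.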